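Chloro in Place of Hydrogen on Compound 3

The compounds below may be only part of what the source reports. "The series", "measured", "known", "first", "only" and "open" are said of these compounds alone.

Compound 1 `COc1ccccc1/C=C/C(=O)c1c(O)cc2occc2c1OC` gives 89100 nM
Compound 2 `COc1c(C(=O)/C=C/c2ccc(Cl)cc2)c(O)c(Br)c2occc12` gives 28800 nM
Compound 3 `C=CCc1c(O)c(C(=O)/C=C/c2ccccc2)c(OC)c2ccoc12` gives 11200 nM

In a functional assay on NCI60 cells (Homo sapiens) for inhibition, with a stated time of 48 h (on this read-out higher numbers stand for weaker inhibition of growth and lower numbers for stronger inhibition of growth), compound 3 has the lowest number of the three, beyond the scatter from both compound 2 and compound 1. Compound 4 `C=CCc1c(O)c(C(=O)/C=C/c2ccc(Cl)cc2)c(OC)c2ccoc12` differs from compound 3 by chloro in place of hydrogen on an aromatic carbon, turning phenyl into 4-chlorophenyl. Within the data shown here, no measured pair isolates this change. Compound 2 also carries 4-chlorophenyl and gives 28800 nM but differs elsewhere too, so it offers only a loose guide. A small step toward a lower number is expected in this assay, probably within the scatter. The expected step is a 1.2-fold lower number from compound 3 to compound 4 (0.09 log units; within the scatter) on this estimate. For compound 4 the estimated value is 9000 nM with an expected range from 4000 nM to 20000 nM in the measurement still to come.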

Compound 4, concentration for total growth inhibition: 11000 nM
Beside the measured number, compound 4's estimate is 1.2-fold (0.09 log units) below it, within the range that was stated.
By their numbers in this assay, from the lowest: compounds 4 and 3 (each within the scatter of the next); then compound 2; then compound 1.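

In this assay, among these compounds, chloro in place of hydrogen on an aromatic carbon gives a 1.0-fold lower number from compound 3 to compound 4 (0.01 log units; within the scatter), the first pair to isolate this change, so phenyl and 4-chlorophenyl cannot be told apart on this allyl compound. With 4-chlorophenyl held fixed, allyl in place of bromo gives a 2.6-fold lower number from compound 2 to compound 4 (0.42 log units; beyond the scatter), so that swap moves the number beyond the scatter while chloro does not. No evidence on the cause accompanies these results. As far as these compounds go, whether an amine or a carboxylic acid at the same ring position would move the number stays open, as does whether chloro behaves alike without the allyl group.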